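Swapping one group on compound 2

A few compounds are considered here, and "the series" means these few. Any claim that something is new, unique, unknown or untested is made for them only; others in the source may bear on it.

For the measured compounds named here, in a functional assay on HL-60 cells (Homo sapiens) for inhibition, read by CCK-8 assay, with a stated time of 48 h (on this read-out higher numbers stand for weaker inhibition and lower numbers for stronger inhibition), compound 2 `O=[N+]([O-])c1cccc(NC(=S)NCCNS(=O)(=O)c2ccc(-c3ccccc3OCc3cccc(O)c3)s2)c1` gives 11400 nM, the only true number so far. Compound 3 `COc1ccc(NC(=O)NCCNS(=O)(=O)c2ccc(-c3ccccc3OCc3cccc(O)c3)s2)cc1` keeps most of compound 2 and changes one part, on an amine nitrogen: a group of 11 heavy atoms (8 carbon, 1 nitrogen, 2 oxygen; one six-membered aromatic ring of carbon only) in place of a group of 12 heavy atoms (7 carbon, 2 nitrogen, 2 oxygen, 1 sulfur; one six-membered aromatic ring of carbon only), on an amine nitrogen. Compound 1 `COc1ccc(NC(=O)NCCNS(=O)(=O)c2ccc(-c3ccccc3OCc3ccccc3)s2)cc1`, which also carries the (4-methoxyphenyl)carbamoyl group, shows > 50000 nM, and that value is a limit of the assay, not a number. This limit points to weaker inhibition, so a modest loss is expected in this assay, an estimated 1.8-fold higher number from compound 2 to compound 3 (0.24 log units; within the scatter). Compound 3 is expected near 20000 nM, with an estimated range of 6000 nM to 50000 nM.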

Compound 3, half-maximal inhibitory concentration: > 20000 nM
Compound 3 gave a limit, no number (the forecaster's own chance of this, stated with the estimate: 35%); the middle value sits exactly at the limit.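

Compound 3 returns only a limit of the assay, not a true number: > 20000 nM. On the amine nitrogen, (4-methoxyphenyl)carbamoyl gives an at least 1.7-fold higher number from compound 2 to compound 3 (0.24 log units; that floor lies within the scatter) in this assay, so this swap brings no gain, though any loss cannot be sized. The step between compound 1 and compound 3 cannot be read, since both values are limits, so the hydroxy group shows no readable effect here.

Going by these compounds, the true size of the swap stays open, as does whether an acetyl group or a longer chain on this nitrogen would give a measurable number.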